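The source may hold more compounds than are shown below. What is called first, only, known or untested is meant among the compounds shown, and "the series" means these compounds.

The measured compounds:

Compound 1, `Cn1nc2c(=O)n(CC3(O)CCN(Cc4ccc(C5CCCO5)cc4Cl)CC3)cnc2c1-c1ccc(CN)cc1`, in an assay on isolated protein for inhibition of ubiquitin carboxyl-terminal hydrolase 7 (Homo sapiens), with stated times of 30 min and 2 h (on this read-out higher numbers stand for weaker inhibition and lower numbers for stronger inhibition), compound 1 gives 3820 nM.
Compound 2, `Cn1nc2c(=O)n(CC3(O)CCN(Cc4ccc(-c5ccoc5)cc4Cl)CC3)cnc2c1-c1ccc(CN)cc1`, in this assay compound 2 gives 177 nM.
Compound 3, `Cn1nc2c(=O)n(CC3(O)CCN(Cc4ccc(-n5cccn5)cc4Cl)CC3)cnc2c1-c1ccc(CN)cc1`, in this assay compound 3 gives 233 nM.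

Compound 3 holds the second highest of the three numbers. Its nearest neighbour is compound 2, with a 1.3-fold higher number from compound 2 to compound 3 (0.12 log units; within the scatter), a gap within the scatter. Its furthest is compound 1, with a 16-fold lower number from compound 1 to compound 3 (1.21 log units; beyond the scatter), a gap beyond the scatter.

The step to compound 4, `Cn1nc2c(=O)n(CC3(O)CCN(Cc4ccc(-c5ccc(C(=O)O)o5)cc4Cl)CC3)cnc2c1-c1ccc(CN)cc1`, is 5-carboxyfuran-2-yl in place of 1H-pyrazol-1-yl on an aromatic carbon.

Within the data shown here, two measured steps bear on this. From the saturated oxolan-2-yl to an aromatic five-membered ring the number fell sharply, both as a 22-fold lower number from compound 1 to compound 2 (1.33 log units; beyond the scatter) and as a 16-fold lower number from compound 1 to compound 3 (1.21 log units; beyond the scatter). Between the two aromatic rings themselves the difference was small, as a 1.3-fold higher number from compound 2 to compound 3 (0.12 log units; within the scatter). Compound 4 keeps an aromatic five-membered ring at that carbon, so the large gain seen against compound 1 is expected to be retained. Among the measured compounds shown here, the added carboxyl has no measured counterpart among the three compounds, so its contribution is unknown, and a step within the scatter is the expected outcome: a 1.1-fold higher number from compound 3 to compound 4 (0.03 log units; within the scatter).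

Compound 4 is therefore estimated at 250 nM in this assay, with a range from 60 nM to 1200 nM.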

Compound 4, half-maximal inhibitory concentration: 753 nM
Beside the measured number, compound 4's estimate is 3.0-fold (0.48 log units) below it; the measured number falls inside the stated range.
By their numbers in this assay, from the lowest: compounds 2 and 3 (each within the scatter of the next); then compound 4; then compound 1.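

In this assay an aromatic five-membered ring at this position no longer fixes the number by itself: with 5-carboxyfuran-2-yl on the aromatic carbon para to a large group, the data show a 3.2-fold higher number from compound 3 to compound 4 (0.51 log units; beyond the scatter) and a 4.3-fold higher number from compound 2 to compound 4 (0.63 log units; beyond the scatter), although the two aromatic rings without a substituent had stayed within the scatter of each other. Part of the gain over the saturated ring survives the change, as a 5.1-fold lower number from compound 1 to compound 4 (0.71 log units; beyond the scatter) shows, so the carboxyl-bearing furan falls short of those two rings yet remains clearly ahead of oxolan-2-yl. Nothing available here explains why the carboxyl-bearing ring gives up part of that gain.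

From the compounds shown here alone, whether the higher number goes with the carboxylic acid itself or with the attachment through furan-2-yl stays open, since compound 4 differs from compound 2 in both at once. Also open, going by these compounds, is how a methyl ester, an amide or an amine in place of the carboxylic acid, or a longer chain carrying that acid, would read in this assay at this position.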